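Trifluoromethoxy in place of trifluoromethyl on the aryl ring

The compounds below may be only part of what the source reports. "The series", "measured", "known", "first", "only" and "open" are said of these compounds alone.

Measured so far in a functional assay on CHO-K1 cells for antagonist activity at succinate receptor 1 (Homo sapiens), read by FLIPR and calcium flux; on this read-out higher numbers stand for weaker inhibition and lower numbers for stronger inhibition:
compound 1, `FC(F)(F)c1ccc(-c2nnc(CCCCc3ccc4cccnc4n3)o2)cc1C(F)(F)F`, compound 1 gives 170 nM
compound 2, `FC(F)(F)c1cc(-c2nnc(CCCCc3ccc4cccnc4n3)o2)ccc1Cl`, compound 2 gives 160 nM
compound 3, `Fc1ccc(-c2nnc(CCCCc3ccc4cccnc4n3)o2)cc1C(F)(F)F`, compound 3 gives 2000 nM

Compound 3 carries the highest number of the three. Its distance to the others is not small: a 12-fold higher number from compound 1 to compound 3 (1.07 log units; beyond the scatter) and a 13-fold higher number from compound 2 to compound 3 (1.10 log units; beyond the scatter), both beyond the scatter, whereas a 1.1-fold lower number from compound 1 to compound 2 (0.03 log units; within the scatter) stays within it. So the group sitting on the aryl ring at this position matters, and fluoro there is clearly the weakest of the three choices seen.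

Compound 4, `Fc1ccc(-c2nnc(CCCCc3ccc4cccnc4n3)o2)cc1OC(F)(F)F`, keeps the fluoro of compound 3 and changes the neighbouring group: trifluoromethoxy in place of trifluoromethyl on an aromatic carbon. Among the measured compounds shown here, no measured step tests trifluoromethoxy directly. For the measured compounds named here, what bears on it is only that the two changes made at this position so far, trifluoromethyl to fluoro and chloro to fluoro, each gave a large upward step, while trifluoromethyl against chloro made no difference. Going from a one-atom fluoro back to a five-heavy-atom group with three fluorines is therefore expected to move the number down again, though with real uncertainty about how far. The expected step is a 5.0-fold lower number from compound 3 to compound 4 (0.70 log units; beyond the scatter), and compound 4 is estimated at 400 nM, between 120 nM and 1400 nM.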

Compound 4, half-maximal inhibitory concentration: 4000 nM
For compound 4 the middle estimate is 10-fold (1.00 log units) below the measured one, outside the stated range (above it).
By their numbers in this assay, from the lowest: compounds 2 and 1 (each within the scatter of the next); then compounds 3 and 4 (each within the scatter of the next).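

In this assay, trifluoromethoxy in place of trifluoromethyl on the aromatic carbon ortho to a fluoro group gives a 2.0-fold higher number from compound 3 to compound 4 (0.30 log units; within the scatter), so compound 3 and compound 4 cannot be told apart. Among the compounds shown here, this is the first look at this group, as the earlier steps varied only the neighbouring fluoro, chloro or trifluoromethyl group; with fluoro held constant, the oxygen of trifluoromethoxy leaves compound 4 in the same high band as compound 3, clearly separate from the band of compound 1 and compound 2. Nothing at hand accounts for this result.

Going by these compounds, the pair reads this exchange only alongside a fluoro group, so whether trifluoromethoxy and trifluoromethyl also stay indistinguishable alongside chloro or a second trifluoromethyl remains open. Also open, on these data alone, is how groups of a different kind, such as a methoxy, a nitrile, an amine or a carboxylic acid, would read on this aromatic carbon, since the two groups compared here both carry three fluorines.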